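Swapping a carbamoylpiperidine for a benzothiazole: expected solubility

The compounds below may be only part of what the source reports. "The series", "measured", "known", "first", "only" and "open" are said of these compounds alone.

Compound 1 `OCC1CCN(c2cccnc2OC2CN(c3ccc4ccccc4n3)C2)CC1`: 189000 nM
Compound 2 `NC(=O)C1CCN(c2nccnc2OC2CN(c3ccc4ccccc4n3)C2)CC1`: 14000 nM

Of the compounds shown here, two have been measured in a physicochemical assay for solubility, in phosphate buffer, at pH 7.4; a higher number here means a more soluble compound, a lower number a less soluble compound. Compound 1 gives 189000 nM, and compound 2 gives 14000 nM, the lower of the two numbers; the gap between them lies beyond the usual scatter. Compound 3 `c1ccc2nc(N3CC(Oc4nccnc4-c4ccc5scnc5c4)C3)ccc2c1` has not yet been measured. It differs from compound 2 in one place: 1,3-benzothiazol-5-yl in place of 4-carbamoylpiperidin-1-yl on an aromatic carbon. Within the data shown here, no step between measured compounds shows what this change does to the read-out, so the expectation rests on the change itself. A downward step a 7.0-fold lower number from compound 2 to compound 3 (0.85 log units; beyond the scatter) is expected, clearly beyond the scatter. The estimate for compound 3 is 2000 nM, within a range from 400 nM to 10000 nM.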

Compound 3, solubility: < 1000 nM
Compound 3 ended at the assay's limit; the forecaster's own chance of this, stated with the estimate: 5%; middle value at least 2.0-fold (0.30 log units) away from the limit.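

In this assay, 1,3-benzothiazol-5-yl in place of 4-carbamoylpiperidin-1-yl on the aromatic carbon next to the ring nitrogen gives a large step, an at least 14-fold lower number from compound 2 to compound 3 (1.14 log units; beyond the scatter). The two groups match in heavy atoms, so at this position, for this pair, the read-out does not follow atom count alone. Compound 3 gives a limit of the assay, not a number: the limit of < 1000 nM in this assay, at which 1 of the 3 values shown sits.

One pair cannot separate what leaving 4-carbamoylpiperidin-1-yl does from what entering 1,3-benzothiazol-5-yl does. Where a morpholine or a carboxylic acid on this carbon would fall remains open.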